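Fluoro for Hydrogen on the Fused Ring of Compound 2

The source may report more compounds than this note shows. Statements on the series, on what has been measured and on what is new or still open speak of the compounds shown alone.

Measured compounds:
compound 1 `CC#C[C@@H](CC(=O)O)c1ccc(OC[C@H]2COc3ccc(Cl)cc3O2)cc1` — 86%
compound 2 `CC#C[C@@H](CC(=O)O)c1ccc(OC[C@H]2COc3ccccc3O2)cc1` — 70%

In a functional assay on HEK293 cells for agonist activity at Free fatty acid receptor 1 (Homo sapiens), read by fluorescence and calcium flux, with a stated time of 10 min (a lower number here means a smaller maximal response, a higher number a larger maximal response), compound 2 gives 70%, the lowest of the two numbers shown. Its nearest neighbour is compound 1, which gives 86% and carries chloro where compound 2 carries hydrogen. Among the measured compounds shown here, the only measured step is a number 16 percentage points lower from compound 1 to compound 2 (beyond the scatter), a modest change that lies beyond the scatter.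

Compound 3 `CC#C[C@@H](CC(=O)O)c1ccc(OC[C@H]2COc3ccc(F)cc3O2)cc1` differs from compound 2 by fluoro in place of hydrogen on an aromatic carbon. For the measured compounds named here, the one step that bears on this change is the chloro-to-hydrogen step, since fluoro is also a halogen; that step was worth a modest amount. Fluoro counts one heavy atom, as chloro does, so a shift in the same direction is expected, but it is estimated to be smaller, a number 8 percentage points higher from compound 2 to compound 3 (within the scatter), within the scatter. Compound 3 is therefore expected to give 78%, with a range from 66% to 90%.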

Compound 3, largest response reached (Emax), in percent of the reference or control that the assay uses: 86%
Estimate against measurement, compound 3: 8 percentage points below; the measured number falls inside the stated range.
By their numbers in this assay, from the lowest: compound 2; then compounds 1 and 3 (each within the scatter of the next).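

In this assay the exchange of hydrogen for fluoro on this aromatic carbon gives a number 16 percentage points higher from compound 2 to compound 3 (beyond the scatter) and so shows that the gain over hydrogen is not confined to chloro. Putting fluoro in place of chloro gives no change at the digits printed from compound 1 to compound 3 (within the scatter) and leaves the two halogens indistinguishable at this position in this read-out, although only chloro had been seen to stand apart from hydrogen before. Nothing at hand explains this result.

The compounds shown leave open whether bromo, or a group that is no halogen at all, such as methyl or methoxy, would keep the larger maximal response on this same carbon. They also leave open whether fluoro or chloro on another carbon of that aromatic ring would do the same.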